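Cytotoxicity notes on the step from compound 2 to compound 3

The source may hold more compounds than are shown below. What is called first, only, known or untested is meant among the compounds shown, and "the series" means these compounds.

Compound 1 `O=c1nc(-c2ccccc2)c2cc(-c3cnc4ccccc4c3)ccc2[nH]1` in an ADME assay on L6 cells (Rattus norvegicus) for cytotoxicity, read by fluorescence and resazurin assay, with a stated time of 72 h (on this read-out higher numbers stand for an effect only at larger amounts of compound and lower numbers for an effect already at smaller amounts), gives only a limit of the assay, > 16000 nM. Compound 1 accounts for (the limit of > 16000 nM in this assay, at which 1 of the 2 values shown sits). For the measured compounds named here, compound 2 `O=c1nc(-c2ccccc2)c2cc(-c3cccc(F)c3)ccc2[nH]1` in this assay gives 23000 nM, the only plain number among the readings so far. Compound 3 `CN1CCN(c2ccc3[nH]c(=O)nc(-c4ccccc4)c3c2)CC1` has not yet been measured in this assay. It differs from compound 2 in one place: 4-methylpiperazin-1-yl in place of 3-fluorophenyl on an aromatic carbon. Going by the values given here, no step between two measured compounds is available, so the size of this change cannot be read off from the data and can only be expected. The expected step from compound 2 to compound 3 in this assay is a 1.1-fold higher number from compound 2 to compound 3 (0.04 log units; within the scatter), a shift not beyond the usual scatter in either direction. For compound 3 in this assay the estimate is 25000 nM, with a range from 10000 nM to 60000 nM.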

Compound 3, half-maximal effective concentration: > 50000 nM
Compound 3 gave a limit, no number (the forecaster's own chance of this, stated with the estimate: 40%); at least 2.0-fold (0.30 log units) between middle value and limit.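

In this assay, 4-methylpiperazin-1-yl in place of 3-fluorophenyl gives an at least 2.1-fold higher number from compound 2 to compound 3 (0.33 log units; beyond the scatter), so this aromatic carbon of the shared core accepts a non-aromatic ring with two hetero atoms with no shift towards effects at smaller amounts. The reading of compound 3 is a limit and not a number, so the step has a minimum size only: the limit of > 50000 nM in this assay, at which 1 of the 3 values shown sits. For the compounds shown here, compound 1 and compound 2 both carry an aromatic ring at this carbon, and this is the first step at this position that can be read.

The compounds shown do not separate the contribution of the non-aromatic ring from that of its two nitrogen atoms. A piperidine, a morpholine or an open-chain amine at this carbon would bear on that question.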